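Trimming a methoxy group from the chalcone aryl ring

This account rests on a few compounds, and the source may have more. Where it says the series, first, only, none or still open, it means among the compounds named here.

Among the compounds with values here, compound 2 `COc1ccc(/C=C/C(=O)c2cc(-c3cc(OC)c(OC)c(OC)c3)n3nc(-c4ccccc4)cc3n2)cc1OC` gives the higher of the two numbers so far in a functional assay on A549 cells (Homo sapiens) for antiproliferative activity, read by MTT assay, with a stated time of 24 h (on this read-out lower numbers stand for stronger inhibition and higher numbers for weaker inhibition), namely 20500 nM; compound 1 `COc1cc(-c2cc(C(=O)/C=C/c3ccccc3)nc3cc(-c4ccccc4)nn23)cc(OC)c1OC` gives 18000 nM, and the two lie within the scatter. The change to compound 3 `COc1ccc(/C=C/C(=O)c2cc(-c3cc(OC)c(OC)c(OC)c3)n3nc(-c4ccccc4)cc3n2)cc1` is hydrogen in place of methoxy on an aromatic carbon. Within the data shown here, the only step that bears on it, a 1.1-fold higher number from compound 1 to compound 2 (0.06 log units; within the scatter), altered the same ring without moving the number beyond the scatter, so no step beyond the scatter is expected here either. Compound 3 is therefore estimated at 19000 nM, between 8000 nM and 45000 nM, a step of a 1.1-fold lower number from compound 2 to compound 3 (0.03 log units; within the scatter).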

Compound 3, half-maximal inhibitory concentration: 21200 nM
Beside the measured number, compound 3's estimate is 1.1-fold (0.05 log units) below it; low and high end bracket the measured number.
By their numbers in this assay, from the lowest: compounds 1, 2 and 3 (each within the scatter of the next).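

In this assay, taking off the methoxy group leaves the number within the scatter (a 1.0-fold higher number from compound 2 to compound 3 (0.01 log units; within the scatter)), and a single methoxy group on the plain phenyl ring of compound 1 also stays within it (a 1.2-fold higher number from compound 1 to compound 3 (0.07 log units; within the scatter)). The phenyl, 4-methoxyphenyl and 3,4-dimethoxyphenyl forms of this ring therefore cannot be told apart on this read-out, whether it carries no, one or two methoxy groups. Nothing available gives a reason for this. On these data alone, whether a different group on this ring, such as an amine, a carboxylic acid or a fluorine atom, would move the number beyond the scatter remains open.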